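The compounds below may be only part of what the source reports. "The series", "measured", "known", "first", "only" and "open" are said of these compounds alone.

The measured compounds:

Compound 1, `CC(C)Sc1nc(O)cc(C(C)c2cccc3ccccc23)n1`, gives 119000 nM in a functional assay on MT4 cells (Homo sapiens) for cytotoxicity; on this read-out lower numbers stand for higher toxicity in this test and higher numbers for lower toxicity in this test.
Compound 2, `CC(c1cc(O)nc(SC2CCCC2)n1)c1cccc2ccccc12`, gives 93000 nM in this assay.
Compound 3, `CC(C)Sc1nc(O)cc(C(C)c2c(Cl)cccc2Cl)n1`, gives 117000 nM in this assay.

Compounds 1 and 2 share a core and differ in one place: cyclopentyl in place of isopropyl on a sulfur. That change made a 1.3-fold lower number from compound 1 to compound 2 (0.11 log units; within the scatter), so the two values cannot be told apart within this test. Compound 3 carries a different core from compound 1, and the difference between the two cores is not broken down here; its value and that of compound 1 are within the scatter of each other, and so are its value and that of compound 2.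

Compound 4, `CC(c1cc(O)nc(SC2CCCC2)n1)c1c(Cl)cccc1Cl`, has not yet been measured in this assay. It stands to compound 3 as compound 2 stands to compound 1: cyclopentyl in place of isopropyl on a sulfur. The place is the same in both pairs, so this is the same change seen once before.

Because that change gave a 1.3-fold lower number from compound 1 to compound 2 (0.11 log units; within the scatter), the step from compound 3 to compound 4 is expected to be small as well, about a 1.2-fold lower number from compound 3 to compound 4 (0.09 log units; within the scatter). On that basis compound 4 is estimated at 95000 nM, expected to fall between 45000 nM and 190000 nM.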

Compound 4, half-maximal cytotoxic concentration: 78300 nM
The estimate for compound 4 lay 1.2-fold (0.08 log units) above the measured number; low and high end bracket the measured number.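

Putting cyclopentyl in place of isopropyl on the sulfur of compound 3 gave a 1.5-fold lower number from compound 3 to compound 4 (0.17 log units; within the scatter) in this assay, so the two values cannot be told apart in this test. Set beside the earlier pair, the change reads alike on both cores: the same change on two cores in this assay, a 1.3-fold lower number (0.11 log units; within the scatter) from compound 1 to compound 2 and a 1.5-fold lower number (0.17 log units; within the scatter) from compound 3 to compound 4, 1.2-fold (0.07 log units) apart, within the scatter of two such steps. This shows that the small step seen on one core was also small on the other, but two pairs do not show that cyclopentyl and isopropyl truly differ in this test, and they say nothing about a third core.

The compounds shown leave open how other groups on the sulfur would read here, such as a longer carbon chain or a chain ending in an amine. Also open, from the compounds shown here alone, is whether a core carrying a carboxylic acid would take the same change in the same way, and everything here concerns cell toxicity alone.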